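A Chloro Group on the Phenyl Ring

The source may report more compounds than this note shows. Statements on the series, on what has been measured and on what is new or still open speak of the compounds shown alone.

Of the compounds shown here, three that share one core have been measured in an assay on a protein complex for binding affinity to Neuronal acetylcholine receptor; alpha4/beta2 (Rattus norvegicus); on this read-out lower numbers stand for stronger inhibition and higher numbers for weaker inhibition. Compound 1 `C#Cc1cncc(O[C@@H]2CCNC2)c1` gives 62 nM. Compound 2 `c1ccc(-c2cncc(O[C@@H]3CCNC3)c2)cc1` gives 1820 nM, the highest of the three numbers, and compound 3 `N#Cc1ccc(-c2cncc(O[C@@H]3CCNC3)c2)cc1` gives 544 nM. The change from the ethynyl group to the phenyl ring brought a 29-fold higher number from compound 1 to compound 2 (1.47 log units; beyond the scatter), while the addition of a cyano group to that phenyl ring brought a 3.3-fold lower number from compound 2 to compound 3 (0.52 log units; beyond the scatter). Compound 4 `Clc1cccc(-c2cncc(O[C@@H]3CCNC3)c2)c1` has not yet been measured in this assay. It differs from compound 2 by chloro in place of hydrogen on an aromatic carbon. Among the measured compounds shown here, of the measured steps, only the one between compound 2 and compound 3 resembles this change, since it too adds a single group onto the phenyl ring of the core, and it lowered the number by a modest amount. Because a 3.3-fold lower number from compound 2 to compound 3 (0.52 log units; beyond the scatter), compound 4 is expected to show a modest decrease in this assay as well, though a different group entering makes this less certain. Compound 4 is therefore estimated at 900 nM, with a range from 300 nM to 2700 nM. This estimate corresponds to an expected step of a 2.0-fold lower number from compound 2 to compound 4 (0.31 log units; beyond the scatter).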

Compound 4, half-maximal inhibitory concentration: 940 nM
Beside the measured number, compound 4's estimate is 1.0-fold (0.02 log units) below it; the measured number falls inside the stated range.
By their numbers in this assay, from the lowest: compound 1; then compounds 3, 4 and 2 (each within the scatter of the next, the first and the last beyond it).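

In this assay, chloro in place of hydrogen on an aromatic carbon, meta to a large group, gives a 1.9-fold lower number from compound 2 to compound 4 (0.29 log units; within the scatter) and so leaves compound 2 and compound 4 indistinguishable on this read-out. Among the compounds shown here, until now the only group added to the phenyl ring was the cyano group, which gave a 3.3-fold lower number from compound 2 to compound 3 (0.52 log units; beyond the scatter) and was a step beyond the scatter, whereas compound 4 shows that a single added group on this ring need not move the number that far, and it is the compound that goes against any such rule. The chlorine is also a small step when set against a 29-fold higher number from compound 1 to compound 2 (1.47 log units; beyond the scatter), and no measured evidence here bears on the reason for this result.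

Compound 3 and compound 4 differ in both the group and its place on the ring, so the compounds shown cannot separate the effect of the group from that of its place. On these data alone, it also stays open whether a larger or differently built group at the chloro position, such as an amine, a methoxy group or a carboxylic acid, would give a step beyond the scatter from compound 2.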